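Changing the aryl group on the ring nitrogen

A few compounds are considered here, and "the series" means these few. Any claim that something is new, unique, unknown or untested is made for them only; others in the source may bear on it.

Measured compounds:
compound 1 `Clc1cccc(Nc2ncc3cccc(OCc4cn(-c5cc(Cl)cc(Cl)c5)nn4)c3n2)c1`: 9000 nM
compound 2 `COc1ccccc1-n1cc(COc2cccc3cnc(Nc4cccc(Cl)c4)nc23)nn1`: > 25000 nM

Both were tested in a functional assay on MDA-MB-231 cells (Homo sapiens) for cytotoxicity, read by cell counting, with a stated time of 48 h; a higher number here means a weaker inhibitor, a lower number a stronger inhibitor. Going by the values given here, compound 1 gives 9000 nM, the only plain number among the values shown. Compound 2 reaches only a limit of the assay, > 25000 nM, and so compound 2 sits at the limit of > 25000 nM in this assay, at which 1 of the 2 values shown sits. Among the compounds with values here, the one measured step, an at least 2.7-fold higher number from compound 1 to compound 2 (0.44 log units; beyond the scatter), replaced the 3,5-dichlorophenyl on the aromatic nitrogen with a 2-methoxyphenyl.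

Compound 3 `Clc1cccc(Nc2ncc3cccc(OCc4cn(-c5ccc(Br)cc5)nn4)c3n2)c1` has not yet been measured. 4-bromophenyl in place of 3,5-dichlorophenyl on an aromatic nitrogen The step that bears on it is an at least 2.7-fold higher number from compound 1 to compound 2 (0.44 log units; beyond the scatter), which moved the number at least modestly toward weaker inhibition when the 3,5-dichlorophenyl was exchanged. Here the entering 4-bromophenyl keeps a halogen, so a smaller shift is expected, close to the scatter or somewhat above it. The expected step is a 1.4-fold higher number from compound 1 to compound 3 (0.16 log units; within the scatter). Compound 3 is therefore estimated at 13000 nM, with a range from 5000 nM to 30000 nM.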

Compound 3, half-maximal inhibitory concentration: 33000 nM
Estimate against measurement, compound 3: 2.5-fold (0.40 log units) below; measured number above the stated range.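

In this assay, the exchange of 3,5-dichlorophenyl for 4-bromophenyl gives a 3.7-fold higher number from compound 1 to compound 3 (0.56 log units; beyond the scatter). Going by these compounds alone, a halogen on the aryl group therefore does not by itself hold the number, and so far the 3,5-dichlorophenyl is the only group on this aromatic nitrogen that gives the lower number, since both the halogen-bearing and the halogen-free replacement move toward weaker inhibition. The step between the 2-methoxyphenyl and the 4-bromophenyl cannot be read, because compound 2 stands at a limit: the limit of > 25000 nM in this assay, at which 1 of the 3 values shown sits.

The compounds shown leave open whether the kind of halogen, the number of halogens or their places on the ring carries the difference, which a 4-chlorophenyl or a 3,5-dibromophenyl would help to separate. They also leave open how a benzyl group, or an aryl group carrying an amine or a carboxylic acid, would read at this position.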